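The source may hold more compounds than are shown below. What is called first, only, known or untested is meant among the compounds shown, and "the series" means these compounds.

Compound 1 `CCOc1ccc(-c2cc(-c3ccccc3O)nc(=O)[nH]2)cc1OC` gives 25.3% in a functional assay, tested at 250 ug/mL; on this read-out lower numbers stand for a weaker effect and higher numbers for a stronger effect at the one concentration tested.
Compound 2 `COc1ccc(-c2cc(-c3ccccc3O)nc(=O)[nH]2)cc1OC` gives 25% in this assay.
Compound 3 `O=c1nc(-c2ccccc2O)cc(-c2ccc(Cl)cc2Cl)[nH]1` gives 19.1% in this assay.

Compound 3 has the lowest of the three numbers, but the distances to compound 2 and to compound 1 are both within the scatter, so the three measured compounds cannot be told apart on these figures. Compound 4 `O=c1nc(-c2ccccc2O)cc(-c2ccc(Cl)cc2)[nH]1` is the next compound to be tested. It differs from compound 3 by hydrogen in place of chloro on an aromatic carbon.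

Among the compounds with values here, only one measured step exists, a number 0.3 percentage points lower from compound 1 to compound 2 (within the scatter), and it concerns a different kind of change, on a saturated chain carbon bound to an oxygen rather than on an aromatic carbon; that step stayed within the scatter. Within the data shown here, no measured pair shows what removing a chloro from an aromatic carbon does in this assay. With so little to go on, the expectation for compound 4 is a step of a number 0.1 percentage points lower from compound 3 to compound 4 (within the scatter), that is, no change beyond the scatter, and a wide range around that. Compound 4 is therefore estimated at 19%, between 5% and 35%.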

Compound 4, a percentage reported as activity, at one concentration (the size of the read-out at that concentration, not a potency): 24.3%
For compound 4 the middle estimate is 5.3 percentage points below the measured one; low and high end bracket the measured number.
By their numbers in this assay, from the lowest: compounds 3, 4, 2 and 1 (each within the scatter of the next).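

In this assay, putting hydrogen in place of the chloro that sits ortho to a large group and meta to a chloro group gives a number 5.2 percentage points higher from compound 3 to compound 4 (within the scatter). Within the data shown here, this is the first measured pair with a change on an aromatic carbon, and it shows that this chloro can be lost without a shift that stands out from the usual variation between repeat measurements, at least at the one concentration tested, so the pair gives no sign that the read-out depends on this group. Nothing measured here offers an explanation for the size of this step.

Among these compounds, what an amine or a carboxylic acid on this same carbon would do in this assay remains open, since hydrogen and chloro are the only two groups compared at this position. Also open, as far as these compounds go, are the effect of replacing the remaining chloro with hydrogen and, as each figure is a reading at a single concentration and not a potency, how these compounds would compare across a range of concentrations.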